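The source may hold more compounds than are shown below. What is called first, only, known or untested is meant among the compounds shown, and "the series" means these compounds.

Working notes on the series.

Three compounds have been run in a functional assay on MGC-803 cells (Homo sapiens) for inhibition, read by MTT assay, with a stated time of 72 h; on this read-out lower numbers stand for stronger inhibition and higher numbers for weaker inhibition. Compound 1 `O=C(/C=C/c1ccc(Cl)cc1)c1ccc(OCCSC(=S)N2CCCC2)cc1` gives 47900 nM. Compound 2 `O=C(/C=C/c1ccc(Cl)cc1)c1ccc(OCCSC(=S)N2CCCCC2)cc1` gives 12800 nM. Compound 3 `O=C(/C=C/c1cc(F)cc(F)c1)c1ccc(OCCCSC(=S)N2CCCC2)cc1` gives 28400 nM. For the measured compounds named here, the one single-point step among them is a 3.7-fold lower number from compound 1 to compound 2 (0.57 log units; beyond the scatter), the only measured change so far that moves the number beyond the scatter.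

Compound 3 stands second highest of the three numbers. Its nearest neighbour is compound 1, whose number lies within the scatter of that of compound 3; compound 2 sits furthest off, at a lower number beyond the scatter.

The next compound, compound 4 `O=C(/C=C/c1ccc(Cl)cc1)c1ccc(OCCCSC(=S)N2CCCC2)cc1`, differs from compound 3 in one place: 4-chlorophenyl in place of 3,5-difluorophenyl on a double-bonded chain carbon bound to a double-bonded chain carbon. Going by the values given here, no measured step bears on this aryl change, since the one step in hand concerns the thiocarbonyl amine, not the aryl group. Compound 1 also carries the 4-chlorophenyl group, and no step between compound 1 and compound 4 is shown, so all that can be said is that compound 1 gives 47900 nM and compound 3 gives 28400 nM, two numbers within the scatter of each other. A step of no more than the scatter is therefore expected, in either direction, as a 1.2-fold higher number from compound 3 to compound 4 (0.09 log units; within the scatter). Compound 4 is estimated at 35000 nM, with a range from 12000 nM to 100000 nM.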

Compound 4, half-maximal inhibitory concentration: 34500 nM
Compound 4: middle estimate off by 1.0-fold (0.01 log units), on the high side; the measured number falls inside the stated range.
By their numbers in this assay, from the lowest: compound 2; then compounds 3, 4 and 1 (each within the scatter of the next).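

For the compounds shown here, in (this assay), the first reading at this position, on a double-bonded chain carbon bound to a double-bonded chain carbon, shows that 4-chlorophenyl in place of 3,5-difluorophenyl stays within the scatter (a 1.2-fold higher number from compound 3 to compound 4 (0.08 log units; within the scatter)), so this pair gives no sign that the aryl change matters with the pyrrolidin-1-yl thiocarbonyl end held fixed. At the other end of the molecule, the group of 9 heavy atoms in place of the group of 8 heavy atoms, each with a five-membered non-aromatic ring, also stays within the scatter (a 1.4-fold lower number from compound 1 to compound 4 (0.14 log units; within the scatter)), whereas the five-membered ring group in place of the six-membered ring group, both of 9 heavy atoms, goes beyond it (a 2.7-fold higher number from compound 2 to compound 4 (0.43 log units; beyond the scatter)), leaving compound 2 apart from compounds 1, 3 and 4. No measured evidence on the reason for these numbers is at hand.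

On these data alone, whether the aryl change stays this small with a piperidin-1-yl end remains open, as does the effect of a 4-methoxyphenyl or an unsubstituted phenyl group at this position. Also open, as far as these compounds go, is how a morpholine ring on the thiocarbonyl carbon, or a longer chain to the aromatic oxygen, would read here.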